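Swapping the aryl group on the nitrogen of compound 2

This account rests on a few compounds, and the source may have more. Where it says the series, first, only, none or still open, it means among the compounds named here.

In a functional assay on HCT-15 cells (Homo sapiens) for antiproliferative activity, read by MTT assay, with a stated time of 72 h (on this read-out higher numbers stand for weaker inhibition and lower numbers for stronger inhibition), compound 1 `CCn1ccnc1-c1cc(OC)c(OC)c(OC)c1` gives > 100000 nM, which is a limit of the assay and not a number. Going by the values given here, compound 2 `COc1cc(-c2nccn2-c2cccc(C)c2)cc(OC)c1OC` gives 1600 nM, the only actual number so far. Compound 3 `COc1ccc(-n2ccnc2-c2cc(OC)c(OC)c(OC)c2)cc1` carries 4-methoxyphenyl in place of 3-methylphenyl on the same aromatic nitrogen (4-methoxyphenyl in place of 3-methylphenyl on an aromatic nitrogen). Among the compounds with values here, the only measured step that bears on this is large: an at least 62-fold lower number from compound 1 to compound 2 (1.79 log units; beyond the scatter). It rests on a limit and replaces ethyl rather than one substituted phenyl with another, so it guides the size only loosely. A modest move is expected in this assay, and the estimated step is a 2.3-fold lower number from compound 2 to compound 3 (0.36 log units; beyond the scatter). For compound 3 the expected value is 700 nM, within a range of 90 nM to 5000 nM.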

Compound 3, half-maximal inhibitory concentration: 1300 nM
Beside the measured number, compound 3's estimate is 1.9-fold (0.27 log units) below it; low and high end bracket the measured number.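

The step of a 1.2-fold lower number from compound 2 to compound 3 (0.09 log units; within the scatter) on replacing 3-methylphenyl with 4-methoxyphenyl shows that these two aryl groups cannot be told apart here, even though the entering group adds an oxygen and a hydrogen-bond acceptor. With an at least 76-fold lower number from compound 1 to compound 3 (1.88 log units; beyond the scatter) as well, the large gain over ethyl holds for both aryl groups shown. Both such steps rest on compound 1, whose value is a limit of the assay: the limit of > 100000 nM in this assay, at which 1 of the 3 values shown sits.

Still open, on these data alone, is how other groups on this nitrogen behave, such as benzyl, a longer chain, or a phenyl bearing an amine or a carboxylic acid. Also open, as far as these compounds go, is whether substituent position matters on its own, since compound 2 and compound 3 differ in both substituent and position.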